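This account rests on a few compounds, and the source may have more. Where it says the series, first, only, none or still open, it means among the compounds named here.

Within the data shown here, the three compounds measured so far share one core and differ in the aryl thioether and the pyridyl group on it. In a functional assay for inhibition of metabotropic glutamate receptor 5 (Homo sapiens), read by FLIPR and calcium flux (on this read-out lower numbers stand for stronger inhibition and higher numbers for weaker inhibition), compound 1 `Clc1ccc(Sc2nccc(-c3ccccn3)n2)cc1Cl` is recorded as "not active" (no number reported), with no number behind that word. Compound 2 `Clc1cccc(Sc2ccnc(-c3ccccn3)n2)c1` gives 620 nM in this assay. Compound 3 `Clc1ccc(Sc2ccnc(-c3cccnc3)n2)cc1` reaches only a limit of this assay, > 10000 nM, which says that inhibition was too weak to yield a number. Compound 3 therefore stands at the limit of > 10000 nM in this assay, at which 1 of the 3 values shown sits, the weakest place on the numbers shown, and one further entry carries no number at all.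

Compound 4 `Clc1ccc(Sc2ccnc(-c3ccncc3)n2)cc1` is not yet measured. It is built from the same atoms as compound 3, joined differently: pyridin-4-yl in place of pyridin-3-yl on an aromatic carbon. Among the measured compounds shown here, because compound 3 stands at > 10000 nM, the only fixed point for this change is a limit, and no step between two numbers shows how moving the ring nitrogen affects inhibition here. Compound 2 shows that a pyridin-2-yl partner can give a number, but compound 4 keeps a different pyridyl group. The step from compound 3 to compound 4 is expected to stay within the scatter, as a step that the limit leaves unreadable from compound 3 to compound 4. For compound 4 the expected value in this assay is 15000 nM, with a range from 4000 nM to 50000 nM, and most likely again only a limit.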

Compound 4, half-maximal inhibitory concentration: > 10000 nM
Compound 4: no number, only a limit (the forecaster's own chance of this, stated with the estimate: 75%); the middle value is on the limit's open side.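

Compound 3 and compound 4 give no readable step for pyridin-4-yl in place of pyridin-3-yl, since neither has a number and both stop at the same limit: the limit of > 10000 nM in this assay, at which 2 of the 4 values shown sit.

The compounds shown leave open how strongly either compound 3 or compound 4 actually inhibits the receptor in this assay, and so whether moving the ring nitrogen matters at all.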